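The source may report more compounds than this note shows. Statements on the series, on what has been measured and on what is new or still open speak of the compounds shown alone.

Of the compounds shown here, two have been measured in a functional assay on the whole organism (strain Kunming) with Mus musculus as the target, with a stated time of 0.5 h, at a dose of 300 mg/kg by the intraperitoneal route; a lower number here means a stronger effect, a higher number a weaker effect of the compound at the dose given. Compound 1 `COc1cc(OC)c(OC)cc1/C=C/COC(=O)/C=C/c1ccc(Br)cc1` carries a bromo group on an aromatic carbon of a six-membered aromatic ring of carbon only. In this assay compound 1 gives 100%. Its closest measured neighbour is compound 2 `COc1cc(OC)c(OC)cc1/C=C/COC(=O)/C=C/c1ccc(OC)c(OC)c1OC`; in this assay compound 2 gives 100%, so compound 1 stands level with compound 2 at the digits shown, the two values lying within the usual scatter of each other.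

Compound 3 `COc1ccc(/C=C/C(=O)OC/C=C/c2cc(OC)c(OC)cc2OC)cc1` is not yet measured. Relative to compound 1 it differs in one place: methoxy in place of bromo on an aromatic carbon. No step between measured compounds exists that matches this change, and the two measured values give no reason to expect a step of any size. The expected step in this assay is no change at the digits printed from compound 1 to compound 3 (within the scatter), none beyond the scatter. Compound 3 is therefore expected to give 100%, with a range from 85% to 100%.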

Compound 3, a percentage reported as activity, at one dose (the size of the read-out at that dose, not a potency): 100%
Beside the measured number, compound 3's estimate shows no gap at the digits printed; low and high end bracket the measured number.
By their numbers in this assay, from the lowest: compounds 1, 2 and 3 (each within the scatter of the next).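

In this assay, for the compounds shown here, the change from 4-bromophenyl to 4-methoxyphenyl gives the first single-place step, and it reads no change at the digits printed from compound 1 to compound 3 (within the scatter). On this aromatic carbon, para to a large group, methoxy in place of bromo therefore leaves the read-out level at the dose given, so this exchange does not separate the two compounds. Nothing available here bears on the reason for this result.

The compounds shown leave open whether an amine, a carboxylic acid or a longer chain at this place would give a different read-out in this assay. Going by these compounds alone, they also leave open which change to the core of compound 1, if any, would bring the number down, since every value so far stands level.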